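Trimethoxyphenyl pyrazole enones: aryl ketone variation

The source may hold more compounds than are shown below. What is called first, only, known or untested is meant among the compounds shown, and "the series" means these compounds.

Measured compounds:
- compound 1, `COc1cc(-c2cc(/C=C/C(=O)c3ccccc3)[nH]n2)cc(OC)c1OC`: in a functional assay on MDA-MB-231 cells (Homo sapiens) for inhibition, read by MTT assay, with a stated time of 48 h (a higher number here means a weaker inhibitor, a lower number a stronger inhibitor), compound 1 gives 2300 nM
- compound 2, `COc1ccc(-c2cc(/C=C/C(=O)c3cc(OC)c(OC)c(OC)c3)[nH]n2)cc1`: in this assay compound 2 gives 2400 nM
- compound 3, `COc1cc(-c2cc(/C=C3\CCCCC3=O)[nH]n2)cc(OC)c1OC`: in this assay compound 3 gives 17800 nM

Compound 1 has the lowest number of the three. The number for compound 2 lies so close to it that the two cannot be told apart within the scatter, so no order is claimed between them. Compound 3, which carries a cyclohexanone in place of the aryl ketone, stands well beyond the scatter from compound 1 and is the clear outlier of the set. Aryl ketones thus sit together near compound 1, while the only non-aromatic ketone falls off.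

Compound 4, `COc1cc(-c2cc(/C=C/C(=O)c3ccc(F)c(F)c3)[nH]n2)cc(OC)c1OC`, is not yet measured. Its difference from compound 1 is counted as 3,4-difluorophenyl in place of phenyl on a carbonyl carbon. The aryl ketone is kept; only the two fluorine atoms are added. Given that compound 1 and compound 2 sit together despite differing on an aromatic ring, no step beyond the scatter is expected in this assay for this change, with at most a slight move toward a lower number. The step from compound 1 to compound 4 is estimated as a 1.3-fold lower number from compound 1 to compound 4 (0.11 log units; within the scatter). Compound 4 is expected to give about 1800 nM, with a range from 700 nM to 5000 nM.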

Compound 4, half-maximal inhibitory concentration: 1500 nM
Beside the measured number, compound 4's estimate is 1.2-fold (0.08 log units) above it, within the range that was stated.
By their numbers in this assay, from the lowest: compounds 4, 1 and 2 (each within the scatter of the next); then compound 3.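

In this assay, 3,4-difluorophenyl in place of phenyl on a carbonyl carbon gives a 1.5-fold lower number from compound 1 to compound 4 (0.19 log units; within the scatter), so the two compounds cannot be told apart and this position accepts the two fluorine atoms without a step beyond the scatter. Before compound 4, no pair in the set differed in one place, which makes this the first direct reading of a change on this aryl ketone, and it shows that the added atoms leave the number inside the scatter of the phenyl parent. No measurement on hand gives a reason for this result or says what the fluorine atoms do here.

A single replacement cannot show how far this tolerance reaches: a carboxylic acid or a dimethylamino group on the phenyl ring, or a pyridine in place of it, could still give a step beyond the scatter. Also open, on these data alone, is whether 3-fluorophenyl or 4-fluorophenyl alone would read the same as 3,4-difluorophenyl, and whether the same change holds on other versions of the core.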